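Working notes: amino in place of hydrogen on compound 2

The source may hold more compounds than are shown below. What is called first, only, known or untested is meant among the compounds shown, and "the series" means these compounds.

Measured so far:
- compound 1 `COc1ccc(-c2c(C#N)[n+]([O-])c3cc(C4OCCO4)ccc3[n+]2[O-])cc1` at 1.4
- compound 2 `O=C(N/N=C/c1ccc2no[n+]([O-])c2c1)c1ccccc1` at 2.2
- compound 3 `N#Cc1c(-c2ccccc2)[n+]([O-])c2ccc(/C=N/NC(=O)c3ccncc3)cc2[n+]1[O-]` at 1

In a physicochemical assay for lipophilicity, read by HPLC, measured as octanol-water partition (on this read-out lower numbers stand for lower lipophilicity and higher numbers for higher lipophilicity), compound 2 holds the highest of the three numbers, at 2.2 on this scale. Both others lie lower, beyond the scatter: compound 1 is the nearest (at 1.4) and compound 3 the furthest (at 1).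

The next compound is compound 4 `Nc1cccc(C(=O)N/N=C/c2ccc3no[n+]([O-])c3c2)c1` and it differs from compound 2 in one place (amino in place of hydrogen on an aromatic carbon), with amino in place of hydrogen on an aromatic carbon, turning phenyl to 3-aminophenyl. Among the measured compounds shown here, no measured pair shows this change, so the expectation rests on the structural change alone and carries a wide range.

A downward step beyond the scatter is expected in this assay and is estimated as a number 0.90 log units lower from compound 2 to compound 4 (beyond the scatter) on this evidence. The expected value for compound 4 is 1.3 (estimated range 0.8 to 1.8).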

Compound 4, partition coefficient: 1.4
Estimate against measurement, compound 4: 0.10 log units below, and the stated range covers the measured number.
By their numbers in this assay, from the lowest: compound 3; then compounds 1 and 4 (each within the scatter of the next); then compound 2.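

In this assay, among the compounds shown here, the series now holds its first step between compounds that differ in one place: amino in place of hydrogen on an aromatic carbon, turning phenyl to 3-aminophenyl, reads as a number 0.80 log units lower from compound 2 to compound 4 (beyond the scatter) and gives the first direct reading of a single change, which the earlier compounds could not offer. The position, on a six-membered aromatic ring of carbon only and meta to a large group, is therefore not silent in this read-out, at least for amino. No measurement at hand bears on why the step has this size.

A single step leaves open whether a carboxylic acid, a methoxy group or a longer chain at this place would move the number in the same direction. It also leaves open whether amino at another carbon of this ring, or on another core, would give a step of similar size.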